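Swapping 4-chlorophenyl for benzamidomethyl on the shared core

A few compounds are considered here, and "the series" means these few. Any claim that something is new, unique, unknown or untested is made for them only; others in the source may bear on it.

Among the compounds with values here, in a functional assay on MCF7 cells (Homo sapiens) for inhibition, read by MTT assay, with a stated time of 72 h (a lower number here means a stronger inhibitor, a higher number a weaker inhibitor), compound 1 (`COc1ccc(-c2nnc(SCCCN3CCN(c4nc5ccccc5o4)CC3)o2)cc1`) gives 52800 nM, and compound 2 (`Clc1ccc(-c2nnc(SCCCN3CCN(c4nc5ccccc5o4)CC3)o2)cc1`) gives 99700 nM, so compound 2 stands within the scatter of its only neighbour. Compound 3 (`O=C(NCc1nnc(SCCCN2CCN(c3nc4ccccc4o3)CC2)o1)c1ccccc1`) carries benzamidomethyl in place of 4-chlorophenyl on an aromatic carbon. Within the data shown here, the only measured step, a 1.9-fold higher number from compound 1 to compound 2 (0.28 log units; within the scatter), puts chloro in place of methoxy and does not test so large an exchange. With this little evidence, no shift beyond the scatter is expected in this assay. The estimated move is a 1.4-fold lower number from compound 2 to compound 3 (0.15 log units; within the scatter). Compound 3 is expected at 70000 nM, within a range of 25000 nM to 170000 nM.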

Compound 3, half-maximal inhibitory concentration: 52700 nM
For compound 3 the middle estimate is 1.3-fold (0.12 log units) above the measured one; the measured number falls inside the stated range.
By their numbers in this assay, from the lowest: compounds 3, 1 and 2 (each within the scatter of the next).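

Exchanging 4-chlorophenyl for benzamidomethyl gives a 1.9-fold lower number from compound 2 to compound 3 (0.28 log units; within the scatter) and exchanging 4-methoxyphenyl for it gives a 1.0-fold lower number from compound 1 to compound 3 (0.00 log units; within the scatter) in this assay even though the entering group adds a hydrogen-bond donor and a hydrogen-bond acceptor. At this position, then, a far bigger exchange than chloro for methoxy still produces no shift beyond the scatter. Nothing available explains this result. As far as these compounds go, whether an amine, a carboxylic acid or a longer chain on this aromatic carbon would move the number beyond the scatter remains open.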